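Replacing 4-hydroxypiperidin-1-yl with piperazin-1-yl in compound 3

A few compounds are considered here, and "the series" means these few. Any claim that something is new, unique, unknown or untested is made for them only; others in the source may bear on it.

In a physicochemical assay for solubility, measured as kinetic solubility (on this read-out lower numbers stand for lower solubility and higher numbers for higher solubility), compound 1 `O=C(Nc1ccnnc1)c1cc(C(F)(F)F)ccc1OCc1ccccc1` gives < 1000 nM, which is a limit of the assay. Compound 2 `CN1CCN(c2ccc(OCc3ccccc3)c(C(=O)Nc3ccnnc3)c2)CC1` reads 228000 nM, and compound 3 `O=C(Nc1ccnnc1)c1cc(N2CCC(O)CC2)ccc1OCc1ccccc1` reads 28000 nM, the lower of the two actual numbers. Replacing trifluoromethyl brought large steps: an at least 220-fold higher number from compound 1 to compound 2 (2.35 log units; beyond the scatter) and an at least 28-fold higher number from compound 1 to compound 3 (1.44 log units; beyond the scatter). Compound 4 `O=C(Nc1ccnnc1)c1cc(N2CCNCC2)ccc1OCc1ccccc1` carries piperazin-1-yl in place of 4-hydroxypiperidin-1-yl on an aromatic carbon. The closest guide is the modest step of an 8.1-fold lower number from compound 2 to compound 3 (0.91 log units; beyond the scatter), which exchanged 4-methylpiperazin-1-yl for 4-hydroxypiperidin-1-yl. Returning to a piperazine should recover most of that step, so a modest rise is expected in this assay. The expected change is a 4.6-fold higher number from compound 3 to compound 4 (0.67 log units; beyond the scatter). For compound 4 the estimated value is 130000 nM, with an expected range of 45000 nM to 350000 nM.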

Compound 4, solubility: 98000 nM
Compound 4: the middle estimate sits 1.3-fold (0.12 log units) above what was measured; the measured number falls inside the stated range.
By their numbers in this assay, from the lowest: compound 3; then compound 4; then compound 2. At a limit, below all of these: compound 1.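

In this assay, the step of a 3.5-fold higher number from compound 3 to compound 4 (0.54 log units; beyond the scatter) shows that exchanging one six-membered ring for another at this position, para to the benzyloxy group, moves the number beyond the scatter. Among these compounds, the step of a 2.3-fold lower number from compound 2 to compound 4 (0.37 log units; beyond the scatter) separates out the methyl on the ring nitrogen, which the earlier compounds did not isolate. The step of an at least 98-fold higher number from compound 1 to compound 4 (1.99 log units; beyond the scatter) starts from a limit, so its true size stays unknown: the limit of < 1000 nM in this assay, at which 1 of the 4 values shown sits.

The compounds shown leave open how a morpholine ring or an open-chain amine would read on this carbon. They also leave open what an ethyl or acetyl group on the ring nitrogen would do in this assay.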